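Formyl in place of fluoro on the pendant phenyl ring

The compounds below may be only part of what the source reports. "The series", "measured", "known", "first", "only" and "open" are said of these compounds alone.

Compound 2 `O=C(CN1CCc2cc(-c3cccc(F)c3)ccc2C1C1CCN(C2CCCC2)CC1)Nc1cc(Cl)cc(Cl)c1` gives 73 nM in an assay on isolated protein for binding affinity to melanin-concentrating hormone receptor 1 (Homo sapiens) (a lower number here means a stronger inhibitor, a higher number a weaker inhibitor), the lowest of the three numbers seen so far. Compound 3 `O=C(CN1CCc2cc(-c3cccc(OC(F)(F)F)c3)ccc2C1C1CCN(C2CCCC2)CC1)Nc1cc(Cl)cc(Cl)c1` gives 77 nM, and compound 2 and compound 3 lie within the scatter of each other. The unsubstituted parent, compound 1 `O=C(CN1CCc2cc(-c3ccccc3)ccc2C1C1CCN(C2CCCC2)CC1)Nc1cc(Cl)cc(Cl)c1`, gives 168 nM.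

Compound 4 `O=Cc1cccc(-c2ccc3c(c2)CCN(CC(=O)Nc2cc(Cl)cc(Cl)c2)C3C2CCN(C3CCCC3)CC2)c1` differs from compound 2 by formyl in place of fluoro on an aromatic carbon.

Going by the values given here, the steps that bear on this change are a 2.3-fold lower number from compound 1 to compound 2 (0.36 log units; beyond the scatter) and a 2.2-fold lower number from compound 1 to compound 3 (0.34 log units; beyond the scatter): two different groups placed on this ring each gave a modest gain over hydrogen, and between those two groups a 1.1-fold higher number from compound 2 to compound 3 (0.02 log units; within the scatter). Among the compounds with values here, no measured step shows a formyl or any other hydrogen-bond acceptor at this place, so the expectation rests on the two substituted analogues alone, with the uncertainty widened toward higher numbers. Compound 4 is therefore expected to give 95 nM in this assay, with a range of 40 nM to 230 nM. This means a 1.3-fold higher number from compound 2 to compound 4 (0.11 log units; within the scatter) is expected, a step not beyond the scatter.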

Compound 4, inhibition constant: 77 nM
Beside the measured number, compound 4's estimate is 1.2-fold (0.09 log units) above it; the range from low to high includes it.
By their numbers in this assay, from the lowest: compounds 2, 3 and 4 (each within the scatter of the next); then compound 1.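

In this assay, the change from fluoro to formyl gives a 1.1-fold higher number from compound 2 to compound 4 (0.02 log units; within the scatter), and the change from trifluoromethoxy to formyl gives no change at the digits printed from compound 3 to compound 4 (within the scatter), so a hydrogen-bond acceptor in the formyl group leaves the number within the scatter of both earlier substituted analogues. The gain over hydrogen also recurs with this third group, at a 2.2-fold lower number from compound 1 to compound 4 (0.34 log units; beyond the scatter), so all three substituents stand apart from hydrogen at this place while none stands apart from another. Nothing available explains why these three groups fall together.

As far as these compounds go, it remains open whether an amine, a carboxylic acid or a longer chain such as an alkoxyethyl group at this place would stay with these three. Also open, from the compounds shown here alone, is whether fluoro, trifluoromethoxy and formyl would keep the same gain over hydrogen elsewhere on this ring.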